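Isopropyl to tert-butyl: one more methyl

A few compounds are considered here, and "the series" means these few. Any claim that something is new, unique, unknown or untested is made for them only; others in the source may bear on it.

Values in a functional assay on MCF7 cells (Homo sapiens) for antiproliferative activity, with a stated time of 72 h (a lower number here means a stronger inhibitor, a higher number a weaker inhibitor), for the compounds measured so far

- compound 1 `C/C(=C\c1csc(C)n1)[C@@H]1C[C@@H]2OC(c3ccccc3)=N[C@H]2CCC[C@H](C)[C@H](O)[C@@H](C)C(=O)C(C)(C)[C@@H](O)CC(=O)O1` gives 19.2 nM
- compound 2 `C/C(=C\c1csc(C)n1)[C@@H]1C[C@@H]2OC(c3ccc(C)cc3)=N[C@H]2CCC[C@H](C)[C@H](O)[C@@H](C)C(=O)C(C)(C)[C@@H](O)CC(=O)O1` gives 1.9 nM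
- compound 3 `C/C(=C\c1csc(C)n1)[C@@H]1C[C@@H]2OC(c3ccc(C(C)C)cc3)=N[C@H]2CCC[C@H](C)[C@H](O)[C@@H](C)C(=O)C(C)(C)[C@@H](O)CC(=O)O1` gives 5140 nM

Compound 3 has the highest number of the three at 5140 nM and is the weakest inhibitor here. Compound 4 `C/C(=C\c1csc(C)n1)[C@@H]1C[C@@H]2OC(c3ccc(C(C)(C)C)cc3)=N[C@H]2CCC[C@H](C)[C@H](O)[C@@H](C)C(=O)C(C)(C)[C@@H](O)CC(=O)O1` carries 4-(tert-butyl)phenyl where compound 3 carries 4-isopropylphenyl, a difference counted as methyl in place of hydrogen on a saturated chain carbon bound to an aromatic carbon and two saturated chain carbons and described as methyl in place of hydrogen on a saturated chain carbon bound to an aromatic carbon and two saturated chain carbons.

Among the compounds with values here, no measured step makes this exact change, so the guidance is indirect. Methyl in place of hydrogen on an aromatic carbon gave a 10-fold lower number from compound 1 to compound 2 (1.00 log units; beyond the scatter) and so a modest gain. Isopropyl in place of that hydrogen gave a 270-fold higher number from compound 1 to compound 3 (2.43 log units; beyond the scatter) and isopropyl in place of methyl gave a 2700-fold higher number from compound 2 to compound 3 (3.43 log units; beyond the scatter) and both are large losses. Compound 2 goes against any simple rule that a bigger group means a higher number. On the strength of a 2700-fold higher number from compound 2 to compound 3 (3.43 log units; beyond the scatter) a further rise is expected, but a much smaller one that may stay close to the usual scatter. The expected change in this assay is a 2.3-fold higher number from compound 3 to compound 4 (0.37 log units; beyond the scatter) and it is only an estimate. For compound 4 the estimated value is 12000 nM with an expected range from 1500 nM to 60000 nM.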

Compound 4, half-maximal inhibitory concentration: > 10000 nM
Compound 4 was reported as a limit; the forecaster's own chance of this, stated with the estimate: 25%; the middle value does not contradict the limit.
By their numbers in this assay, from the lowest: compound 2; then compound 1; then compound 3. At a limit, above all of these: compound 4.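

In this assay compound 4 gives > 10000 nM, which is a limit of the assay and not a number: the limit of > 10000 nM in this assay, at which 1 of the 4 values shown sits.

Set against the two compounds with the smallest groups, the loss is clear, with an at least 5200-fold higher number from compound 2 to compound 4 (3.72 log units; beyond the scatter) and an at least 520-fold higher number from compound 1 to compound 4 (2.71 log units; beyond the scatter), so the poor result of compound 3 is not confined to isopropyl, and tert-butyl on the same aromatic carbon also ends far from both. As far as these compounds go, the single added methyl gives an at least 1.9-fold higher number from compound 3 to compound 4 (0.28 log units; that floor lies within the scatter), and as that floor lies within the scatter, compound 3 and compound 4 cannot be put in order, and the true size of this step stays unknown.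

The compounds shown leave open where between methyl and isopropyl the steep rise sets in, a question that an ethyl or a straight propyl chain in place of the methyl of compound 2 would address. Also open, from the compounds shown here alone, is whether a methoxy group, an amine or a carboxylic acid on that aromatic carbon would stay near compound 2, which gives 1.9 nM, or fall with the branched alkyl groups.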